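Swapping a pyridyl thioether chain for a bromophenyl thioether

This account rests on a few compounds, and the source may have more. Where it says the series, first, only, none or still open, it means among the compounds named here.

Of the compounds shown here, two of a shared core have been measured so far. In an assay on H9c2 cells for inhibition of tumor necrosis factor receptor superfamily member 6 (Rattus norvegicus), with stated times of 30 min and 6 h (on this read-out higher numbers stand for an effect only at larger amounts of compound and lower numbers for an effect already at smaller amounts), compound 1 `COC(=O)c1oc2ccccc2c1NC(=O)CSc1ccc([N+](=O)[O-])cc1` gives 575 nM, and compound 2 `COC(=O)c1oc2cccc(Cl)c2c1NC(=O)CCSc1ccccn1` gives 631 nM, so the two values lie within the usual scatter of each other. Compound 3 `COC(=O)c1oc2cccc(Cl)c2c1NC(=O)CSc1ccc(Br)cc1` carries (4-bromophenyl)sulfanyl in place of ((pyridin-2-yl)sulfanyl)methyl on a saturated chain carbon bound to a carbonyl carbon. Within the data shown here, no measured pair shows this exact change, so the step is expected to be small in this assay, with no clear direction beyond the scatter, because compound 1 with its phenyl thioether already gives 575 nM. Compound 3 is therefore expected to give about 550 nM, between 200 nM and 1500 nM, which is an expected step of a 1.1-fold lower number from compound 2 to compound 3 (0.06 log units; within the scatter).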

Compound 3, half-maximal effective concentration: 1150 nM
Compound 3: the middle estimate sits 2.1-fold (0.32 log units) below what was measured, within the range that was stated.
By their numbers in this assay, from the lowest: compounds 1, 2 and 3 (each within the scatter of the next).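

In this assay, replacing ((pyridin-2-yl)sulfanyl)methyl with (4-bromophenyl)sulfanyl on a saturated chain carbon bound to a carbonyl carbon gives a 1.8-fold higher number from compound 2 to compound 3 (0.26 log units; within the scatter), so this single change has no effect that can be told apart from the scatter. At this position, a ring of carbon only carrying bromine and a ring with a nitrogen cannot be told apart on this read-out. No measurement shown here offers an explanation for this result. On these data alone, it remains open whether an amine or a carboxylic acid in place of the bromine would shift the value beyond the scatter. As far as these compounds go, the effect of a longer chain at this position also remains open.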